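Ethyl to Trifluoromethyl on the Aromatic Ring

The source may hold more compounds than are shown below. What is called first, only, known or untested is meant among the compounds shown, and "the series" means these compounds.

Measured so far:
Compound 1, `O=C(O)CCCSCCN1C(=O)SC[C@@H]1/C=C/[C@@H](O)Cc1ccccc1`: 0.65 nM
Compound 2, `CCCc1cccc(C[C@H](O)/C=C/[C@H]2CSC(=O)N2CCSCCCC(=O)O)c1`: 0.98 nM
Compound 3, `CCc1cccc(C[C@H](O)/C=C/[C@H]2CSC(=O)N2CCSCCCC(=O)O)c1`: 0.88 nM

In an assay on CHO cells for displacement of a labelled ligand from prostaglandin E2 receptor EP4 subtype (Mus musculus), read by scintillation counting, with a stated time of 60 min (a lower number here means a stronger inhibitor, a higher number a weaker inhibitor), compound 3 gives 0.88 nM, the second highest of the three numbers. Its nearest neighbour is compound 2, with a 1.1-fold lower number from compound 2 to compound 3 (0.05 log units; within the scatter), and its furthest is compound 1, with a 1.4-fold higher number from compound 1 to compound 3 (0.13 log units; within the scatter); neither gap rises above the scatter of the method. Compound 4, `O=C(O)CCCSCCN1C(=O)SC[C@@H]1/C=C/[C@@H](O)Cc1cccc(C(F)(F)F)c1`, has not yet been measured. It differs from compound 3 in one place: trifluoromethyl in place of ethyl on an aromatic carbon.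

Within the data shown here, two measured steps touch the same aromatic carbon. From compound 1 to compound 3 an ethyl took the place of a hydrogen, with a 1.4-fold higher number from compound 1 to compound 3 (0.13 log units; within the scatter); from compound 1 to compound 2 a propyl took that place, with a 1.5-fold higher number from compound 1 to compound 2 (0.18 log units; within the scatter). Both lie inside the scatter, so substitution at this carbon has so far moved the number very little. No measured compound carries a trifluoromethyl, so the account for compound 4 rests on this limited record. A step of no more than the usual scatter is expected from compound 3 to compound 4, a 1.1-fold higher number from compound 3 to compound 4 (0.06 log units; within the scatter). Compound 4 is therefore estimated at 1 nM in this assay, between 0.4 nM and 2.5 nM.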

Compound 4, inhibition constant: 0.97 nM
Compound 4: middle estimate off by 1.0-fold (0.01 log units), on the high side; measured number inside the range.
By their numbers in this assay, from the lowest: compounds 1, 3, 4 and 2 (each within the scatter of the next).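

In this assay, trifluoromethyl on this aromatic carbon gives a 1.5-fold higher number from compound 1 to compound 4 (0.17 log units; within the scatter), so a group that carries fluorine, and not only an alkyl chain, can replace the hydrogen without a step beyond the scatter. Set against the alkyl groups at the same carbon, the exchange for ethyl gives a 1.1-fold higher number from compound 3 to compound 4 (0.04 log units; within the scatter) and the exchange for propyl gives a 1.0-fold lower number from compound 2 to compound 4 (0.00 log units; within the scatter), which shows that the 3-ethylphenyl and 3-(trifluoromethyl)phenyl compounds cannot be told apart here, and that the same holds for the propyl compound. The record at this position therefore now spans a hydrogen, two alkyl chains and a fluorinated group, all within the scatter of one another, but nothing available explains why the numbers stay so close.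

The compounds shown leave open how this carbon would respond to an amine, a carboxylic acid or a chain longer than propyl, any of which might produce the first step beyond the scatter at this position. They also leave open whether trifluoromethyl would read the same on another carbon of the aromatic ring.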